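The source may hold more compounds than are shown below. What is called first, only, known or untested is meant among the compounds shown, and "the series" means these compounds.

Within the data shown here, in a functional assay on Bel-7402 cells (Homo sapiens) for cytotoxicity, read by MTT assay, with a stated time of 72 h (a lower number here means a stronger inhibitor, a higher number a weaker inhibitor), two esters of the shared core have numbers so far. Compound 1 (`C=C1C(=O)[C@@]23C(=O)OC[C@]4(C(=O)CCC(C)(C)[C@H]4C=O)[C@@H]2CC[C@@H]1[C@H]3OC(=O)c1ccc(C(F)(F)F)cc1`) gives 3990 nM, and compound 2 (`C=C1C(=O)[C@@]23C(=O)OC[C@]4(C(=O)CCC(C)(C)[C@H]4C=O)[C@@H]2CC[C@@H]1[C@H]3OC(=O)c1ccc([N+](=O)[O-])cc1`) gives 3300 nM. Among the measured compounds shown here, compound 2 therefore stands level with compound 1, the only other measured compound, and the two cannot be told apart. Compound 3 (`C=C1C(=O)[C@@]23C(=O)OC[C@]4(C(=O)CCC(C)(C)[C@H]4C=O)[C@@H]2CC[C@@H]1[C@H]3OC(=O)c1ccccc1Cl`) has yet to be measured. It has 2-chlorophenyl in place of 4-nitrophenyl on a carbonyl carbon.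

For the measured compounds named here, only one measured step bears on this change, and only indirectly: a 1.2-fold lower number from compound 1 to compound 2 (0.08 log units; within the scatter), with nitro in place of trifluoromethyl on an aromatic carbon. That exchange left the number within the scatter. Neither measured compound carries 2-chlorophenyl, however, so the evidence is thin and the range must stay wide. No step beyond the scatter is therefore expected in this assay, and no direction can be favoured. The expected change is a 1.1-fold higher number from compound 2 to compound 3 (0.03 log units; within the scatter). For compound 3, the estimated value is 3500 nM, with an expected range of 1500 nM to 8000 nM.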

Compound 3, half-maximal inhibitory concentration: 2890 nM
For compound 3 the middle estimate is 1.2-fold (0.08 log units) above the measured one; the range from low to high includes it.
By their numbers in this assay, from the lowest: compounds 3, 2 and 1 (each within the scatter of the next).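

In this assay, the exchange of 4-nitrophenyl for 2-chlorophenyl on a carbonyl carbon gives a 1.1-fold lower number from compound 2 to compound 3 (0.06 log units; within the scatter), and the exchange of 4-(trifluoromethyl)phenyl for 2-chlorophenyl at the same place gives a 1.4-fold lower number from compound 1 to compound 3 (0.14 log units; within the scatter). Among these compounds, both earlier esters carried a 4-substituted phenyl, so this is the first result at this place for a group with a different substitution pattern and a different substituent, with chlorine entering and the nitrogen and oxygen of the nitro group leaving, and all three esters still cannot be told apart in this assay. The data shown offer no explanation for why these three groups give indistinguishable numbers.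

Going by these compounds, all three compounds carry a substituted phenyl on this carbonyl carbon, so it remains open whether the number would hold with an unsubstituted phenyl, a longer alkyl chain in place of the ring, or a phenyl bearing an amine or a carboxylic acid. On these data alone, it is also open whether 2-chlorophenyl and its 4-chlorophenyl counterpart would give matching numbers, which would separate the effect of where the substituent sits from that of which substituent it is.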